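Growth Inhibition by Symmetric and Asymmetric Acylguanidines

A few compounds are considered here, and "the series" means these few. Any claim that something is new, unique, unknown or untested is made for them only; others in the source may bear on it.

Measured compounds:
compound 1, `CC(C)=CC(=O)NC(=N)NC(=O)C=C(C)C`: 45600 nM
compound 2, `CC(C)=CCC/C(C)=C/C(=O)NC(=N)NC(=O)C=C(C)C`: 36200 nM
compound 3, `CC(C)=CCC/C(C)=C/CC/C(C)=C/C(=O)NC(=N)NC(=O)/C=C(\C)CC/C=C(\C)CCC=C(C)C`: 9200 nM

The three measured compounds were tested in a functional assay on U-373MG ATCC cells for inhibition, with U373 MG (Homo sapiens) as the target, read by MTT assay, with a stated time of 72 h; on this read-out higher numbers stand for weaker inhibition of growth and lower numbers for stronger inhibition of growth. In this assay compound 1 gives 45600 nM, compound 2 gives 36200 nM and compound 3 gives 9200 nM. Compound 3 shows the strongest inhibition of growth among the three, its steps to compound 2 and to compound 1 both lying beyond the scatter. Between compound 2 and compound 1 the change is hydrogen in place of 3-methylbut-2-en-1-yl on a saturated chain carbon bound to a double-bonded chain carbon, and the step was a 1.3-fold higher number from compound 2 to compound 1 (0.10 log units; within the scatter). The difference between the cores of compound 3 and compound 2 is not broken down here.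

Compound 4, `CC(C)=CCC/C(C)=C/CC/C(C)=C/C(=O)NC(=N)NC(=O)/C=C(\C)CCC=C(C)C`, has not yet been measured. It differs from compound 3 by hydrogen in place of 3-methylbut-2-en-1-yl on a saturated chain carbon bound to a double-bonded chain carbon. Within the data shown here, this is the same change as the one from compound 2 to compound 1, and the place is described in the same words, so it is the same kind of change on a larger core. Since that earlier step stayed within the scatter, compound 4 is expected to remain close to compound 3, with an expected step of a 1.4-fold higher number from compound 3 to compound 4 (0.15 log units; within the scatter) in this assay. The estimate for compound 4 is 13000 nM, between 6000 nM and 28000 nM, resting on the small step recorded from compound 2 to compound 1.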

Compound 4, concentration for 50% growth inhibition: 35000 nM
For compound 4 the middle estimate is 2.7-fold (0.43 log units) below the measured one, and the stated range ends below it.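

In this assay, hydrogen in place of 3-methylbut-2-en-1-yl on a saturated chain carbon bound to a double-bonded chain carbon does not have the same size of effect on the two cores: the same change on two cores in this assay, a 1.3-fold higher number (0.10 log units; within the scatter) from compound 2 to compound 1 and a 3.8-fold higher number (0.58 log units; beyond the scatter) from compound 3 to compound 4, 3.0-fold (0.48 log units) apart, beyond the scatter of two such steps

On the core of compound 3 the change counts, with a 3.8-fold higher number from compound 3 to compound 4 (0.58 log units; beyond the scatter), whereas 3,7-dimethylocta-2,6-dien-1-yl in place of hydrogen at that same kind of place gives a 1.0-fold lower number from compound 2 to compound 4 (0.01 log units; within the scatter), so compound 2 and compound 4 cannot be told apart and only compound 3 stands clearly away from them. This shows that a small step on one core in this series cannot simply be carried to another core, but with just one pair on each core it gives no rule for how the step depends on the core, and it does not say why the two steps differ.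

The compounds shown leave open whether the step would grow gradually or appear only once both chains reach the length found in compound 3. They also leave open how a longer chain, a fully saturated chain or a chain ending in an amine or a carboxylic acid would behave on these cores.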